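Swapping chloro for cyano on the E stilbene

This account rests on a few compounds, and the source may have more. Where it says the series, first, only, none or still open, it means among the compounds named here.

Within the data shown here, in a functional assay on HUVEC cells (Homo sapiens) for inhibition, with a stated time of 4 days (on this read-out lower numbers stand for stronger inhibition and higher numbers for weaker inhibition), compound 1 (`COc1ccc(C(N)=O)cc1/C=C/c1ccc(Cl)cc1`) gives 87 nM, the lower of the two numbers measured so far. Compound 2 (`COc1ccc(C(N)=O)cc1/C=C\c1ccc(Cl)cc1`) gives 2900 nM. This large step, a 33-fold higher number from compound 1 to compound 2 (1.52 log units; beyond the scatter), can be put down to the double bond, given (the fact that compounds 1 and 2 differ only in the configuration as drawn). Compound 3 (`COc1ccc(C(N)=O)cc1/C=C/c1ccc(C#N)cc1`) keeps the E double bond and changes one group: cyano in place of chloro on an aromatic carbon. That is cyano in place of chloro on an aromatic carbon. Among the measured compounds shown here, the only measured step concerns the double bond and leaves this position untouched, so it says nothing direct about the swap. Compound 3 shares its double bond with compound 1 at 87 nM, so a drop as large as a 33-fold higher number from compound 1 to compound 2 (1.52 log units; beyond the scatter) is not expected, and no step beyond the scatter is expected in this assay. The expected change is small, a 1.7-fold higher number from compound 1 to compound 3 (0.24 log units; within the scatter). For compound 3 the estimate is 150 nM, with an expected range of 40 nM to 600 nM.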

Compound 3, half-maximal inhibitory concentration: 3100 nM
The estimate for compound 3 lay 21-fold (1.32 log units) below the measured number; the whole stated range lies below it.
By their numbers in this assay, from the lowest: compound 1; then compounds 2 and 3 (each within the scatter of the next).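

This position does not accept every swap: in this assay, cyano in place of chloro gives a 36-fold higher number from compound 1 to compound 3 (1.55 log units; beyond the scatter), even with the E double bond kept. The double bond alone therefore does not settle the read-out, and a change on this aromatic carbon, para to a large group, also counts as a large step. Nothing given here bears on why cyano and chloro differ at this position.

From the compounds shown here alone, with only chloro and cyano at this position, it remains open whether a fluoro, a methyl or an amine would stay close to compound 1 or land nearer compound 3. Going by these compounds, it is also open whether the cyano group would give a similar result with the Z double bond of compound 2.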